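A few compounds are considered here, and "the series" means these few. Any claim that something is new, unique, unknown or untested is made for them only; others in the source may bear on it.

Working notes on a thiazole series tested in a functional assay on A549 cells (Homo sapiens) for antiproliferative activity, read by MTT assay, with a stated time of 72 h; a higher number here means a weaker inhibitor, a lower number a stronger inhibitor.

Compound 1 `COc1ccc(-c2sc(N(C)C)nc2-c2cc(OC)c(OC)c(OC)c2)cc1` reaches only the limit > 10000 nM in this assay, a limit rather than a number. Compound 2 `CCOc1ccc(-c2sc(N(C)C)nc2-c2cc(OC)c(OC)c(OC)c2)cc1` likewise returns only the limit > 10000 nM. Within the data shown here, compound 3 `COc1ccc(-c2sc(C)nc2-c2cc(OC)c(OC)c(OC)c2)cc1` is the single compound with a measured number, giving 2560 nM in this assay.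

The cores of compound 1 and compound 3 differ by methyl in place of dimethylamino on an aromatic carbon, and this exchange gives an at least 3.9-fold lower number from compound 1 to compound 3 (0.59 log units; beyond the scatter). The change from compound 1 to compound 2 is methyl in place of hydrogen on a saturated chain carbon bound to an oxygen on an aromatic ring; its size is a step that the two limits leave unreadable from compound 1 to compound 2, which cannot be read because the limit of > 10000 nM in this assay, at which 2 of the 3 values shown sit, holds both values.

Compound 4 `CCOc1ccc(-c2sc(C)nc2-c2cc(OC)c(OC)c(OC)c2)cc1` is still to be measured in this assay. It differs from compound 3 by methyl in place of hydrogen on a saturated chain carbon bound to an oxygen on an aromatic ring, the same change as that from compound 1 to compound 2, at the same place. Among the measured compounds shown here, the one measured instance of this change is unreadable, so the expectation for compound 4 is not anchored by a readable step; it is expected to stay near the number of compound 3 with a step of a 1.1-fold higher number from compound 3 to compound 4 (0.04 log units; within the scatter). In this assay compound 4 is estimated at 2800 nM, between 1000 nM and 8000 nM.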

Compound 4, half-maximal inhibitory concentration: 3320 nM
Beside the measured number, compound 4's estimate is 1.2-fold (0.07 log units) below it, within the range that was stated.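

Carried to the core of compound 2, methyl in place of dimethylamino on an aromatic carbon gives an at least 3.0-fold lower number from compound 2 to compound 4 (0.47 log units; beyond the scatter), so in this assay the direction seen on the core of compound 1 recurs on a second core: the same change on two cores in this assay, an at least 3.9-fold lower number (0.59 log units; beyond the scatter) from compound 1 to compound 3 and an at least 3.0-fold lower number (0.47 log units; beyond the scatter) from compound 2 to compound 4; the limit leaves it open whether they differ

This shows a shared direction but not a shared size, since each step starts from a limit and gives only a minimum: the limit of > 10000 nM in this assay, at which 2 of the 4 values shown sit.

Methoxy to ethoxy gives a 1.3-fold higher number from compound 3 to compound 4 (0.11 log units; within the scatter), which is the only readable instance of that change, as the step on the dimethylamino core cannot be read, so its transfer between cores remains untested.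

The compounds shown leave open how a primary amine or an ethyl group on that aromatic carbon would compare with methyl. They also leave open whether a longer chain such as propoxy in place of ethoxy would remain within the scatter of compound 3 and compound 4.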